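Swapping the carbonyl ring: thiophene to pyridine

The source may hold more compounds than are shown below. What is called first, only, known or untested is meant among the compounds shown, and "the series" means these compounds.

Three compounds share one core and differ only in the ring attached to a carbonyl carbon. Compound 1 `COc1ccc(-c2cc3ccccc3nc2/C=C/C(=O)c2ccccc2)cc1` carries a phenyl there and gives 7410 nM in a functional assay on A549 cells (Homo sapiens) for antiproliferative activity, read by XTT assay, with a stated time of 72 h; on this read-out higher numbers stand for weaker inhibition and lower numbers for stronger inhibition. Compound 2 `COc1ccc(-c2cc3ccccc3nc2/C=C/C(=O)c2ccco2)cc1` carries a furan-2-yl and gives 6130 nM; the step of a 1.2-fold lower number from compound 1 to compound 2 (0.08 log units; within the scatter) stays within the scatter. Compound 3 `COc1ccc(-c2cc3ccccc3nc2/C=C/C(=O)c2cccs2)cc1` carries a thiophen-2-yl and gives 920 nM, the lowest of the three numbers, with steps an 8.1-fold lower number from compound 1 to compound 3 (0.91 log units; beyond the scatter) and a 6.7-fold lower number from compound 2 to compound 3 (0.82 log units; beyond the scatter) both beyond the scatter.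

Compound 4 `COc1ccc(-c2cc3ccccc3nc2/C=C/C(=O)c2ccccn2)cc1` is not yet measured. Its change from compound 3 is pyridin-2-yl in place of thiophen-2-yl on a carbonyl carbon. The two measured steps into compound 3 show that the two other rings tried on this carbonyl carbon, phenyl and furan-2-yl, give clearly higher numbers than thiophen-2-yl, and that a six-membered ring and a five-membered ring with one hetero atom land close together. A pyridin-2-yl shares features with both, so a return toward their range is expected, as a 4.3-fold higher number from compound 3 to compound 4 (0.64 log units; beyond the scatter). For compound 4 the expected value in this assay is 4000 nM, with a range from 1200 nM to 13000 nM.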

Compound 4, half-maximal inhibitory concentration: 6140 nM
Compound 4: the middle estimate sits 1.5-fold (0.19 log units) below what was measured; low and high end bracket the measured number.
By their numbers in this assay, from the lowest: compound 3; then compounds 2, 4 and 1 (each within the scatter of the next).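

The step of a 6.7-fold higher number from compound 3 to compound 4 (0.82 log units; beyond the scatter) in this assay shows that a six-membered ring with one nitrogen does not keep the low number of compound 3. The step of a 1.0-fold higher number from compound 2 to compound 4 (0.00 log units; within the scatter) and the step of a 1.2-fold lower number from compound 1 to compound 4 (0.08 log units; within the scatter) both stay within the scatter, so pyridin-2-yl falls level with furan-2-yl and phenyl on this carbonyl carbon. Among the four rings, thiophen-2-yl alone stands apart, and a hetero atom in the ring is not enough for that: furan-2-yl and pyridin-2-yl each carry one without reaching the number of compound 3.

What sets thiophen-2-yl apart stays open, as no measurement here speaks to a cause. On these data alone, it is also open whether thiophen-3-yl or thiazol-2-yl, a ring holding both sulfur and nitrogen, would stay near compound 3.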